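Swapping Dichlorophenyl for Dimethoxyphenyl on a Diamine Core

The compounds below may be only part of what the source reports. "The series", "measured", "known", "first", "only" and "open" are said of these compounds alone.

Of the compounds shown here, three built on the same core have been tested in a functional assay on SF-268 cells (Homo sapiens) for inhibition, read by sulforhodamine B assay, with a stated time of 48 h; a higher number here means a weaker inhibitor of growth, a lower number a stronger inhibitor of growth. Compound 1 `Nc1cc(N)c2nc(-c3ccccc3)c(NCc3ccc(Cl)c(Cl)c3)nc2c1` gives 55000 nM in this assay. Compound 2 `CCOC(=O)[C@H](CCC(=O)O)NC(=O)c1ccc(Sc2nc3cc(N)cc(N)c3nc2-c2ccccc2)cc1` gives 44700 nM, and compound 3 `Nc1cc(N)c2nc(-c3ccccc3)c(Sc3ccc(Cl)c(Cl)c3)nc2c1` gives 51300 nM. Among these three, the number for compound 1 is the highest, yet its gap to compound 3 and to compound 2 lies within the usual scatter of repeated measurements, so the three compounds cannot be told apart on growth inhibition.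

Compound 4 `COc1ccc(CNc2nc3cc(N)cc(N)c3nc2-c2ccccc2)cc1OC` has not yet been measured. It differs from compound 1 in one place: 3,4-dimethoxyphenyl in place of 3,4-dichlorophenyl on a saturated chain carbon bound to a nitrogen on an aromatic ring. Within the data shown here, no measured pair shows the effect of such a change on this core, so the expectation rests only on the three values known, all of which sit close together.

In this assay compound 4 is therefore expected to give about 60000 nM, with a likely range from 25000 nM to 140000 nM. This estimate amounts to a step of a 1.1-fold higher number from compound 1 to compound 4 (0.04 log units; within the scatter), expected to stay within the scatter rather than to mark a real change in either direction.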

Compound 4, concentration for total growth inhibition: 60300 nM
Compound 4: the middle estimate sits 1.0-fold (0.00 log units) below what was measured; the measured number falls inside the stated range.
By their numbers in this assay, from the lowest: compounds 2, 3, 1 and 4 (each within the scatter of the next).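

In this assay, among these compounds, this is the first pair on the shared core that differs in one place: 3,4-dimethoxyphenyl in place of 3,4-dichlorophenyl on a saturated chain carbon bound to a nitrogen on an aromatic ring gives a 1.1-fold higher number from compound 1 to compound 4 (0.04 log units; within the scatter). At this position, then, two chlorine atoms can be exchanged for two methoxy groups, which adds two hydrogen-bond acceptors and two heavy atoms, with no change that can be told from the scatter. Nothing measured here offers an explanation for this lack of change.

This single pair cannot show whether any group at this position would shift growth inhibition beyond the scatter. A longer chain carrying the ring, or a pyridine ring in place of 3,4-dimethoxyphenyl, remains an open case.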